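Imidazolyl amide on a shared benzimidazole-carboxamide scaffold

This account rests on a few compounds, and the source may have more. Where it says the series, first, only, none or still open, it means among the compounds named here.

Measured compounds:
Compound 1, `CCCn1c(NC(=O)c2cc(C)nn2CC)nc2cc(C(N)=O)ccc21`: > 100000 nM
Compound 2, `CCCn1c(NC(=O)c2ccc3ccccc3n2)nc2cc(C(N)=O)cc(OC)c21`: > 100000 nM
Compound 3, `CCCn1c(NC(=O)c2ccnn2CC)nc2cc(C(N)=O)cc(OC)c21`: > 100000 nM

All three values come from an assay for activation of interferon regulatory factor 3 (Homo sapiens), read by a luciferase reporter, with a stated time of 20 h (on this read-out lower numbers stand for an effect already at smaller amounts and higher numbers for an effect only at larger amounts of compound), and every one of them is a limit of the assay rather than a number. For compound 2 only such a limit is known, > 100000 nM, and it stands at the limit of > 100000 nM in this assay, at which 3 of the 3 values shown sit, together with the other two.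

The change from compound 2 to compound 4, `CCCn1c(NC(=O)c2cncn2C)nc2cc(C(N)=O)cc(OC)c21`, is 1-methyl-1H-imidazol-5-yl in place of quinolin-2-yl on a carbonyl carbon. The nearest measured step is a step that the two limits leave unreadable from compound 2 to compound 3, which also swapped the quinolin-2-yl for a small five-membered azole on the same carbonyl carbon, but both ends sit at the limit, so its size cannot be read. Within the data shown here, no measured step therefore gives a direction for this change, and the expectation is that compound 4 stays at the same limit.

Compound 4 is estimated at 100000 nM, within 30000 nM to 300000 nM. The estimated step of a number no higher from compound 2 to compound 4 (the limit leaves the size open) is accordingly expected to show no change beyond the scatter.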

Compound 4, half-maximal effective concentration: > 100000 nM
Compound 4: no number, only a limit (the forecaster's own chance of this, stated with the estimate: 85%); the middle value sits exactly at the limit.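

Among these compounds, compound 2, compound 3 and compound 4 all stop at a limit of the assay, so no step among them can be read: the limit of > 100000 nM in this assay, at which 4 of the 4 values shown sit. The compounds shown leave open whether any group on this carbonyl carbon gives a measurable effect.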